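Replacing the Trifluoromethoxyphenyl with Chlorophenyl

A few compounds are considered here, and "the series" means these few. Any claim that something is new, unique, unknown or untested is made for them only; others in the source may bear on it.

Of the compounds shown here, three built on one shared core have been measured in a functional assay on U-87MG ATCC cells (Homo sapiens) for inhibition, read by MTT assay, with a stated time of 72 h; a lower number here means a stronger inhibitor, a higher number a weaker inhibitor. Compound 1 `COc1cc2c(Oc3ccc(NC(=O)c4nn(-c5ccccc5C)c(=O)cc4C)cc3F)ccnc2cc1OCCCN1CCCC1` gives 2960 nM. Compound 2 `COc1cc2c(Oc3ccc(NC(=O)c4nn(-c5ccccc5OC(F)(F)F)c(=O)cc4C)cc3F)ccnc2cc1OCCCN1CCCC1` gives 1280 nM, the second highest of the three numbers. Compound 3 `COc1cc2c(Oc3ccc(NC(=O)c4nn(-c5ccccc5OC(F)(F)F)c(=O)cc4C)cc3F)ccnc2cc1OCCCN1CCC(C)CC1` gives 800 nM. The step of a 2.3-fold lower number from compound 1 to compound 2 (0.36 log units; beyond the scatter) is the only one that alters the aryl group on the ring nitrogen; the step of a 1.6-fold lower number from compound 2 to compound 3 (0.20 log units; within the scatter) concerns the amine at the end of the chain.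

Compound 4 `COc1cc2c(Oc3ccc(NC(=O)c4nn(-c5ccc(Cl)cc5)c(=O)cc4C)cc3F)ccnc2cc1OCCCN1CCCC1` differs from compound 2 by 4-chlorophenyl in place of 2-(trifluoromethoxy)phenyl on an aromatic nitrogen. Going by the values given here, only the step from compound 1 to compound 2 bears on this position, and it was modest; the present swap is a different one, and no measured pair shows where a chlorine on the far side of that phenyl ring leads. The expected step in this assay is a 1.2-fold higher number from compound 2 to compound 4 (0.07 log units; within the scatter), with no clear direction beyond the scatter. Compound 4 is therefore estimated at 1500 nM, within a range from 500 nM to 4500 nM.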

Compound 4, half-maximal inhibitory concentration: 1430 nM
For compound 4 the middle estimate is 1.0-fold (0.02 log units) above the measured one; the measured number falls inside the stated range.
By their numbers in this assay, from the lowest: compounds 3, 2 and 4 (each within the scatter of the next); then compound 1.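

Swapping 2-(trifluoromethoxy)phenyl for 4-chlorophenyl on the aromatic nitrogen gives a 1.1-fold higher number from compound 2 to compound 4 (0.05 log units; within the scatter) in this assay, so these two aryl groups cannot be told apart in this read-out. Replacing the 2-methylphenyl of compound 1 with 4-chlorophenyl gives a 2.1-fold lower number from compound 1 to compound 4 (0.32 log units; beyond the scatter), which means that, among the three aryl groups now seen here, 2-methylphenyl alone stands apart from the other two. Nothing at hand explains this result.

The compounds shown do not separate the effect of the chlorine from that of its place on the ring, which a 2-chlorophenyl or a 4-(trifluoromethoxy)phenyl group would address. Going by these compounds, how an unsubstituted phenyl group would read here also remains open, as does whether 4-chlorophenyl would pair with the 4-methylpiperidin-1-yl group of compound 3 in the same way.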